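The source may report more compounds than this note shows. Statements on the series, on what has been measured and on what is new or still open speak of the compounds shown alone.

Compounds measured so far:

compound 2, `O=C(N[C@H]1CC[C@@H](c2ccccc2)CC1)c1[nH]c(=O)[nH]c(=O)c1O` — 26 nM
compound 1, `Nc1c(C(=O)N[C@H]2CC[C@@H](c3ccccc3)CC2)[nH]c(=O)[nH]c1=O` — 91 nM

In an assay on cells for inhibition of endothelial lipase (Homo sapiens), read by LC-MS, with stated times of 10 min and 30 min (on this read-out higher numbers stand for weaker inhibition and lower numbers for stronger inhibition), compound 2 gives the lowest of the two numbers shown; the nearest is compound 1, which gives 91 nM in this assay, a step of a 3.5-fold lower number from compound 1 to compound 2 (0.54 log units; beyond the scatter). Compound 3, `O=C(N[C@H]1CC[C@@H](c2ccccc2)CC1)c1[nH]c(=O)n(Cc2ccccc2)c(=O)c1O`, is not yet measured. It differs from compound 2 by benzyl in place of hydrogen on an aromatic nitrogen. No measured step touches this ring nitrogen; the only step shown concerns a hydroxy in place of an amino group, so it gives no guide here. Compound 3 is therefore estimated at 40 nM, with a wide range from 10 nM to 200 nM, a step of a 1.5-fold higher number from compound 2 to compound 3 (0.19 log units; within the scatter) that is expected to stay within the scatter.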

Compound 3, half-maximal inhibitory concentration: 117 nM
Compound 3: middle estimate off by 2.9-fold (0.47 log units), on the low side; measured number inside the range.
By their numbers in this assay, from the lowest: compound 2; then compounds 1 and 3 (each within the scatter of the next).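

In this assay, among the compounds shown here, the first change at this ring nitrogen moves the number clearly: benzyl in place of hydrogen gives a 4.5-fold higher number from compound 2 to compound 3 (0.65 log units; beyond the scatter). Even with this added aromatic ring, compound 3 still gives 117 nM, so substitution here weakens inhibition without abolishing it. Nothing available explains the step.

As far as these compounds go, it remains open whether methyl or a longer chain such as phenethyl on this nitrogen would give a smaller step. From the compounds shown here alone, it is also open whether the step follows from losing the hydrogen or from the added ring.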